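A few compounds are considered here, and "the series" means these few. Any claim that something is new, unique, unknown or untested is made for them only; others in the source may bear on it.

Compound 1 `Fc1cccc(-c2nc(Nc3ccccc3F)c3cc(F)ccc3n2)c1` was examined in a functional assay on U2OS cells (Homo sapiens) for cytotoxicity, read by MTT assay, with a stated time of 48 h; a higher number here means a weaker inhibitor, a lower number a stronger inhibitor. In this assay compound 1 returns only a limit, > 50000 nM, rather than a number. Two near relatives were measured beside it. Compound 2 `Fc1cccc(-c2nc(Nc3cccc(Br)c3)c3cc(F)ccc3n2)c1` carries 3-bromophenyl in place of 2-fluorophenyl on a nitrogen on an aromatic ring, and in this assay compound 2 likewise reaches only a limit, > 50000 nM. Compound 3 `Fc1cccc(-c2nc(Nc3ccccc3Br)c3cc(F)ccc3n2)c1` has bromo in place of fluoro on an aromatic carbon, and in this assay compound 3 also stops at a limit, > 50000 nM. The steps a step that the two limits leave unreadable from compound 1 to compound 2, a step that the two limits leave unreadable from compound 1 to compound 3 and a step that the two limits leave unreadable from compound 2 to compound 3 therefore cannot be sized, as the limit of > 50000 nM in this assay, at which 3 of the 3 values shown sit.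

Compound 4 `Oc1ccccc1Nc1nc(-c2cccc(F)c2)nc2ccc(F)cc12` differs from compound 1 by hydroxy in place of fluoro on an aromatic carbon. Among the measured compounds shown here, none of the measured steps touches this change, and none of them yields a readable size, so no direction or magnitude beyond the scatter can be drawn from them for this assay. With every measured relative sitting at the limit, compound 4 is expected to give about 60000 nM, within a range from 20000 nM to 200000 nM, and most probably another limit. That estimate amounts to an expected step that the limit leaves unreadable from compound 1 to compound 4.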

Compound 4, half-maximal inhibitory concentration: 41400 nM
Compound 4: middle estimate off by 1.4-fold (0.16 log units), on the high side, and the stated range covers the measured number.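

With hydroxy on this aromatic carbon, ortho to a large group, compound 4 returns a number in this assay, while each relative returns only a limit: the limit of > 50000 nM in this assay, at which 3 of the 4 values shown sit.

Hydroxy in place of fluoro gives an at least 1.2-fold lower number from compound 1 to compound 4 (0.08 log units; that floor lies within the scatter), hydroxy in place of bromo gives an at least 1.2-fold lower number from compound 3 to compound 4 (0.08 log units; that floor lies within the scatter), and 2-hydroxyphenyl in place of 3-bromophenyl gives an at least 1.2-fold lower number from compound 2 to compound 4 (0.08 log units; that floor lies within the scatter). All three steps are floors resting on limits, so this position is shown to allow a readable value with hydroxy, but no change beyond the scatter is established.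

How far compounds 1, 2 and 3 truly lie from compound 4 cannot be read, and the steps among those three cannot be read either. From the compounds shown here alone, whether an amine or a methoxy group on this same aromatic carbon would also return a number in this assay remains open.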